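This account rests on a few compounds, and the source may have more. Where it says the series, first, only, none or still open, it means among the compounds named here.

Compound 1 `O=C(/C=C/c1coc2cc(O)ccc2c1=O)NCc1ccccc1` gives, as a limit of a functional assay on L02 cells (Homo sapiens) for inhibition, read by MTT assay, with a stated time of 48 h (on this read-out lower numbers stand for stronger inhibition and higher numbers for weaker inhibition), and not a number, > 200000 nM.
Compound 2 `COc1ccc2c(=O)c(/C=C/C(=O)NCc3ccccc3)coc2c1` gives, again as a limit of this assay, > 200000 nM.
Compound 3 `COc1ccc2c(=O)c(/C=C/C(=O)Nc3ccccc3)coc2c1` gives, also as a limit of this assay, > 200000 nM.

All three measured compounds therefore sit at the same place, namely (the limit of > 200000 nM in this assay, at which 3 of the 3 values shown sit). Among the compounds with values here, compound 3 stands at that limit, and so do the two others, so no measured compound is separated from another. The two steps between neighbours, a step that the two limits leave unreadable from compound 1 to compound 2 and a step that the two limits leave unreadable from compound 2 to compound 3, cannot be read for size or direction, since both ends of each are limits.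

Compound 4 `COc1ccc(CNC(=O)/C=C/c2coc3cc(OC)ccc3c2=O)cc1` differs from compound 3 in one place: 4-methoxybenzyl in place of phenyl on an amide-type nitrogen. Neither measured step bears on this change, and the measured steps give no readable size at all, so there is no ground from the numbers shown for expecting a move in either direction beyond the scatter. The most probable outcome is that compound 4 is expected to remain at the limit as well, with the expected step being a step that the limit leaves unreadable from compound 3 to compound 4. On that basis compound 4 is estimated at 300000 nM in this assay, with an expected range from 100000 nM to 1000000 nM.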

Compound 4, half-maximal inhibitory concentration: > 200000 nM
Compound 4: only a limit was reported (the forecaster's own chance of this, stated with the estimate: 85%); the middle value lies beyond the limit too.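

Compound 4 also gives only a limit, so its steps from compound 2 and from compound 3 cannot be read for size or direction. All four compounds now share one place: the limit of > 200000 nM in this assay, at which 4 of the 4 values shown sit.

The compounds shown leave open whether any of these changes has an effect in this assay, in either direction.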